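Selenocyanates on THP-1 cells: nitro to cyano

The source may hold more compounds than are shown below. What is called first, only, known or untested is meant among the compounds shown, and "the series" means these compounds.

Measured so far in an ADME assay on THP-1 cells (Homo sapiens) for cytotoxicity, read by trypan blue exclusion, with a stated time of 24 h; a higher number here means a weaker inhibitor, a lower number a stronger inhibitor:
compound 1 `N#C[Se]Cc1cccc([N+](=O)[O-])c1` gives 9320 nM
compound 2 `N#C[Se]Cc1ccccc1[N+](=O)[O-]` gives 7100 nM
compound 3 `N#C[Se]Cc1cccc(C#N)c1` gives 7600 nM

Compound 2 and compound 1 have the same atoms joined differently; the difference between the two cores is not broken down here. Compound 2 and compound 3 lie within the scatter of each other, as do compound 3 and compound 1 and compound 2 and compound 1, so no ordering among the three is claimed.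

One change is seen in a measured pair: cyano in place of nitro on an aromatic carbon. That pair gives a 1.2-fold lower number from compound 1 to compound 3 (0.09 log units; within the scatter), a step that is within the scatter.

Compound 4 `N#C[Se]Cc1ccccc1C#N` is not yet measured. It differs from compound 2 by cyano in place of nitro on an aromatic carbon. This is the same kind of change as from compound 1 to compound 3, not the same: there the cyano stands meta to a group of 4 heavy atoms, here ortho to a group of 4 heavy atoms. A single measured instance of the change at a different place is a thin basis, so the expectation rests on compound 2 at 7100 nM and on the small size of a 1.2-fold lower number from compound 1 to compound 3 (0.09 log units; within the scatter).

For compound 4 a step of a 1.1-fold lower number from compound 2 to compound 4 (0.06 log units; within the scatter) is expected. Compound 4 is thus estimated at 6200 nM in this assay, with a range from 3000 nM to 12500 nM.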

Compound 4, half-maximal inhibitory concentration: 17100 nM
Beside the measured number, compound 4's estimate is 2.8-fold (0.44 log units) below it; the whole stated range lies below it.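

In this assay, cyano in place of nitro on an aromatic carbon gives a 2.4-fold higher number from compound 2 to compound 4 (0.38 log units; beyond the scatter). The change therefore does not carry over at one size from the core of compound 1 to the core of compound 2: the same change on two cores in this assay, a 1.2-fold lower number (0.09 log units; within the scatter) from compound 1 to compound 3 and a 2.4-fold higher number (0.38 log units; beyond the scatter) from compound 2 to compound 4, 3.0-fold (0.47 log units) apart, beyond the scatter of two such steps. Within the data shown here, this shows that the step on one core is a poor guide to the step on the other in this small set, but it does not show why the two steps part, and with only one pair per core it gives no rule for any further core.

The compounds shown carry only nitro or cyano on the ring, so it stays open whether a methoxy group, a chlorine atom, an amine or a carboxylic acid would follow the step seen on the core of compound 1 or the one seen on the core of compound 2. Also open, as far as these compounds go, is whether the gap between the two steps would persist with a longer chain carrying the selenocyanate, or with a sulfur atom in place of selenium.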